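Ethoxycarbonyl for Trifluoromethyl: Expecting a Small Step

This account rests on a few compounds, and the source may have more. Where it says the series, first, only, none or still open, it means among the compounds named here.

Of the compounds shown here, three sharing one core have been measured in an ADME assay on the whole organism with Oryza sativa as the target, tested at 1 uM; on this read-out lower numbers stand for a stronger effect and higher numbers for a weaker effect at the one concentration tested. Compound 1, `CC(C)c1ccc(NC(=O)N[C@H](C)c2ccccc2)cc1`, gives 79%. Compound 2, `C[C@@H](NC(=O)Nc1ccc(C(C)(C)C)cc1)c1ccccc1`, gives 88% in this assay. Compound 3, `C[C@@H](NC(=O)Nc1ccc(C(F)(F)F)cc1)c1ccccc1`, gives 89% in this assay. On the numbers shown, compound 3 holds the highest of the three, yet its nearest neighbour is compound 2 with the step of a number 1 percentage points higher from compound 2 to compound 3 (within the scatter) and its furthest is compound 1 with the step of a number 10 percentage points higher from compound 1 to compound 3 (within the scatter); both steps stay inside the scatter, so no order among the three can be claimed.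

Compound 4, `CCOC(=O)c1ccc(NC(=O)N[C@H](C)c2ccccc2)cc1`, has not yet been measured. It differs from compound 3 in one place: ethoxycarbonyl in place of trifluoromethyl on an aromatic carbon. Of the measured steps, a number 10 percentage points higher from compound 1 to compound 3 (within the scatter) and a number 1 percentage points higher from compound 2 to compound 3 (within the scatter) touch the same aromatic carbon, para to a large group, and neither moved the read-out beyond the scatter; the step of a number 9 percentage points higher from compound 1 to compound 2 (within the scatter) sits elsewhere and was also within the scatter. Going by the values given here, no measured step brings in an ethoxycarbonyl, so nothing points to a shift in a particular direction. The change is therefore expected to be small, with a number 5 percentage points lower from compound 3 to compound 4 (within the scatter) as the estimated step. Among the compounds with values here, the range is left wide, as the entering group has no counterpart among the measured compounds. Compound 4 is expected to give 84%, between 62% and 100%.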

Compound 4, a percentage reported as activity, at one concentration (the size of the read-out at that concentration, not a potency): 100%
Compound 4: the middle estimate sits 16 percentage points below what was measured, within the range that was stated.
By their numbers in this assay, from the lowest: compounds 1, 2 and 3 (each within the scatter of the next); then compound 4.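

At this position, on an aromatic carbon para to a large group, ethoxycarbonyl is the only one of the four groups shown that separates from the others beyond the scatter in this assay: it gives a number 11 percentage points higher from compound 3 to compound 4 (beyond the scatter), a number 12 percentage points higher from compound 2 to compound 4 (beyond the scatter) and a number 21 percentage points higher from compound 1 to compound 4 (beyond the scatter), each a modest step towards a weaker effect at the one concentration tested. The position therefore does respond to the group it carries, even though isopropyl, tert-butyl and trifluoromethyl could not be told apart there, and the exchange for trifluoromethyl brings in 2 hydrogen-bond acceptors where the leaving group has 0. No measurement at hand bears on what lies behind this shift.

The compounds shown leave open whether the step belongs to the whole ethoxycarbonyl group or to only part of it, since a carboxylic acid, a methoxycarbonyl group or a primary amide at the same place would be needed to separate the carbonyl from the ethyl chain. They also leave open how a longer ester chain or an amine on this aromatic carbon would read.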